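This account rests on a few compounds, and the source may have more. Where it says the series, first, only, none or still open, it means among the compounds named here.

Measured in a physicochemical assay for solubility, read by HPLC, using the shake flask method, measured as kinetic solubility, with a stated time of 2 h, at pH 7.4; a lower number here means a less soluble compound, a higher number a more soluble compound:
compound 1 `Cc1cc(NCc2ccccn2)n2ncc(Br)c2n1`: 89300 nM
compound 2 `Cc1cc(NCc2ccccn2)n2ncc(-c3c(C)cccc3C)c2n1`: < 5000 nM (a limit of the assay)
compound 3 `Cc1cc(NCc2ccccn2)n2ncc(C3=CCC(F)(F)CC3)c2n1`: 5000 nM

Compound 3 gives the lowest number among the two numbers read in this assay; its nearest neighbour is compound 1, with an 18-fold lower number from compound 1 to compound 3 (1.25 log units; beyond the scatter). The value of compound 2 is a limit only (the limit of < 5000 nM in this assay, at which 1 of the 3 values shown sits). Compound 4 `Cc1cc(NCc2ccccn2)n2ncc(-c3cncnc3)c2n1` differs from compound 3 in one place: pyrimidin-5-yl in place of 4,4-difluorocyclohex-1-en-1-yl on an aromatic carbon. For the measured compounds named here, the steps that bear on this are an 18-fold lower number from compound 1 to compound 3 (1.25 log units; beyond the scatter) and an at least 17-fold lower number from compound 1 to compound 2 (1.25 log units; beyond the scatter), both large and both in the direction of lower solubility when a ring replaces bromo; the step of a number no lower from compound 2 to compound 3 (the limit leaves the size open) gives no readable size. Going by the values given here, no measured step covers the entry of a pyrimidin-5-yl. For compound 4 the estimate is 25000 nM (range 7000 nM to 90000 nM), which would be the expected step of a 5.0-fold higher number from compound 3 to compound 4 (0.70 log units; beyond the scatter) in this assay.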

Compound 4, solubility: 111000 nM
Compound 4: the middle estimate sits 4.4-fold (0.65 log units) below what was measured; measured number outside the range, above it.
By their numbers in this assay, from the lowest: compound 3; then compounds 1 and 4 (each within the scatter of the next).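

In this assay, a ring on this aromatic carbon does not by itself set a low number, since the outcome changes with the ring that enters: a 22-fold higher number from compound 3 to compound 4 (1.35 log units; beyond the scatter) and an at least 22-fold higher number from compound 2 to compound 4 (1.34 log units; beyond the scatter). The value of compound 2 is a limit: the limit of < 5000 nM in this assay, at which 1 of the 4 values shown sits. Among the rings shown, pyrimidin-5-yl alone reads level with bromo, a 1.2-fold higher number from compound 1 to compound 4 (0.09 log units; within the scatter).

Open, from the compounds shown here alone, is whether an unsubstituted phenyl or a pyridyl on this carbon would read with pyrimidin-5-yl or with 4,4-difluorocyclohex-1-en-1-yl. Also open, going by these compounds, is how an amine or a carboxylic acid on the pyrimidine ring would read.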